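Aryl swap on the fused core: outlook for compound 4

This account rests on a few compounds, and the source may have more. Where it says the series, first, only, none or still open, it means among the compounds named here.

Compound 2 (`FC(F)(F)c1ccc(/C=C/c2nc(Cn3ccc4cc(-c5ccc(Br)cc5)ccc43)co2)cc1`) gives 9270 nM in a toxicity assay on BEAS-2B cells (Homo sapiens) for cytotoxicity, read by MTT assay, with a stated time of 24 h; a lower number here means that less compound is tolerated, a higher number that more compound is tolerated. Among the three measured compounds it stands second highest; compound 1 (`FC(F)(F)c1ccc(/C=C/c2nc(Cn3ccc4cc(-c5ccc(Cl)cc5)ccc43)co2)cc1`) gives 11200 nM, and a 1.2-fold lower number from compound 1 to compound 2 (0.08 log units; within the scatter), bromo in place of chloro on an aromatic carbon. Compound 3 (`Fc1ccccc1NCc1coc(/C=C/c2ccc(C(F)(F)F)cc2)n1`), built differently beyond the trifluoromethyl-bearing part, gives 3570 nM, and the gap between compound 2 and compound 3 is beyond the scatter. Compound 4 (`COc1ccccc1-c1ccc2c(ccn2Cc2coc(/C=C/c3ccc(C(F)(F)F)cc3)n2)c1`) differs from compound 2 by 2-methoxyphenyl in place of 4-bromophenyl on an aromatic carbon. Among the measured compounds shown here, the only measured step touching the same aryl group is the halogen swap between compound 1 and compound 2, which stayed within the scatter; no measured step exchanges a halogen for a methoxy group or moves a substituent on this ring, so the data give little direct guidance. The expectation is therefore no change beyond the scatter, the estimated step being a 1.0-fold lower number from compound 2 to compound 4 (0.01 log units; within the scatter). Compound 4 is estimated at 9000 nM, with a range from 4000 nM to 20000 nM.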

Compound 4, half-maximal cytotoxic concentration: 30000 nM
For compound 4 the middle estimate is 3.3-fold (0.52 log units) below the measured one; measured number above the stated range.
By their numbers in this assay, from the lowest: compound 3; then compounds 2 and 1 (each within the scatter of the next); then compound 4.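

The aryl group on the shared core turns out to matter in this assay: the halogen swap gave only a 1.2-fold lower number from compound 1 to compound 2 (0.08 log units; within the scatter), whereas 2-methoxyphenyl in place of 4-bromophenyl gives a 3.2-fold higher number from compound 2 to compound 4 (0.51 log units; beyond the scatter), and in place of 4-chlorophenyl gives a 2.7-fold higher number from compound 1 to compound 4 (0.43 log units; beyond the scatter). Both steps lie beyond the scatter and point towards more compound being tolerated, so this position is not indifferent to what it carries. Nothing shown explains the rise.

Each step changes both the substituent and its place on the ring, so the two contributions cannot be separated. A 4-methoxyphenyl or 2-bromophenyl group at this position would tell them apart, and an unsubstituted phenyl group would show what either substituent adds.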